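The source may hold more compounds than are shown below. What is called first, only, known or untested is meant among the compounds shown, and "the series" means these compounds.

Notes on the series in a functional assay on PANC-1 cells (Homo sapiens) for inhibition, read by MTT assay, with a stated time of 24 h; on this read-out lower numbers stand for stronger inhibition and higher numbers for weaker inhibition. Compound 1 `CC1(C)[C@H]2CC[C@]1(C)N(Cc1cn(-c3ccc(O)cc3)nn1)C(=O)C2` gives 100 nM, compound 2 `CC1(C)[C@H]2CC[C@]1(C)N(Cc1cn(-c3ccc(Br)cc3)nn1)C(=O)C2` gives 200 nM and compound 3 `CC1(C)[C@H]2CC[C@]1(C)N(Cc1cn(-c3ccccc3O)nn1)C(=O)C2` gives 230 nM. Compound 3 has the highest number of the set, but two steps qualify that position: a 1.2-fold higher number from compound 2 to compound 3 (0.06 log units; within the scatter), and a 2.3-fold higher number from compound 1 to compound 3 (0.36 log units; beyond the scatter). It therefore cannot be separated from compound 2 and stands apart only from compound 1.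

The next structure is compound 4 `Cc1cccc(-n2cc(CN3C(=O)C[C@@H]4CC[C@@]3(C)C4(C)C)nn2)c1`, with the change 3-methylphenyl in place of 2-hydroxyphenyl on an aromatic nitrogen. For the measured compounds named here, no measured compound carries 3-methylphenyl, so the data give no direct read on this group.

Three exchanges on the same nitrogen substituent bear on it. Compound 2 has no hydroxy group, and the exchange of hydroxy for bromo stayed small, a 2.0-fold higher number from compound 1 to compound 2 (0.30 log units; within the scatter). Going by the values given here, the swap of whole aryl groups is the closest precedent, and it also stayed small, a 1.2-fold higher number from compound 2 to compound 3 (0.06 log units; within the scatter). Among the compounds with values here, the only step beyond the scatter is modest, a 2.3-fold higher number from compound 1 to compound 3 (0.36 log units; beyond the scatter).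

No shift beyond the scatter is therefore expected in this assay, and the expected step is a 1.2-fold lower number from compound 3 to compound 4 (0.06 log units; within the scatter). The estimate for compound 4 is 200 nM, with an expected range from 90 nM to 450 nM.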

Compound 4, half-maximal inhibitory concentration: 240 nM
For compound 4 the middle estimate is 1.2-fold (0.08 log units) below the measured one; the range from low to high includes it.
By their numbers in this assay, from the lowest: compounds 1, 2, 3 and 4 (each within the scatter of the next, the first and the last beyond it).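

Working from this assay, the exchange from 2-hydroxyphenyl, with 1 hydrogen-bond donor and 1 hydrogen-bond acceptor, to 3-methylphenyl, with 0 of each, gives a 1.0-fold higher number from compound 3 to compound 4 (0.02 log units; within the scatter) and so adds a first methyl-bearing aryl group that cannot be separated from the hydroxy-bearing compound 3; the exchange from 4-bromophenyl gives a 1.2-fold higher number from compound 2 to compound 4 (0.08 log units; within the scatter) and places compound 4 with compound 2 as well. For the compounds shown here, the one separation that compound 4 adds is against 4-hydroxyphenyl, with a 2.4-fold higher number from compound 1 to compound 4 (0.38 log units; beyond the scatter) as a modest step, so compound 1 now stands apart from both compound 3 and compound 4, while its step to compound 2 remains within the scatter. No measurement at hand explains why these aryl groups read as they do.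

The compounds shown leave open whether any group on this aryl ring can move the number further, as an amine, a carboxylic acid or a longer chain such as propyl might test. They also leave open whether the edge of compound 1 belongs to the 4-hydroxyphenyl group specifically, a question that 3-hydroxyphenyl and 4-methylphenyl would address directly.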